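Swapping 3-methoxyphenyl for 4-methylphenyl on the shared core

A few compounds are considered here, and "the series" means these few. Any claim that something is new, unique, unknown or untested is made for them only; others in the source may bear on it.

- Compound 1 `Cc1ccc(-c2nn(-c3ccccc3)cc2C(Nc2nc3cc(C)c(C)cc3s2)c2c(O)ccc3ccccc23)cc1`: 22400 nM
- Compound 2 `Cc1cc2nc(NC(c3cn(-c4ccccc4)nc3-c3ccc([N+](=O)[O-])cc3)c3c(O)ccc4ccccc34)sc2cc1C`: 41100 nM
- Compound 3 `COc1cccc(-c2nn(-c3ccccc3)cc2C(Nc2nc3ccccc3s2)c2c(O)ccc3ccccc23)c1`: 16900 nM

For the measured compounds named here, in a functional assay on MCF7 cells (Homo sapiens) for antiproliferative activity, read by MTT assay, with a stated time of 48 h (on this read-out lower numbers stand for stronger inhibition and higher numbers for weaker inhibition), compound 3 gives 16900 nM, within the scatter of compound 1 and lower than compound 2, the only one of the pair separated from it beyond the scatter. Compound 4 `Cc1ccc(-c2nn(-c3ccccc3)cc2C(Nc2nc3ccccc3s2)c2c(O)ccc3ccccc23)cc1` differs from compound 3 by 4-methylphenyl in place of 3-methoxyphenyl on an aromatic carbon. Going by the values given here, no measured step makes this exact change. Among the compounds with values here, the only measured step, a 1.8-fold higher number from compound 1 to compound 2 (0.26 log units; within the scatter), is nitro in place of methyl on an aromatic carbon and lies within the scatter. Compound 1 also carries 4-methylphenyl, on a different core, and gives 22400 nM. No step beyond the scatter is therefore expected in this assay. The expected change is a 1.2-fold higher number from compound 3 to compound 4 (0.07 log units; within the scatter). For compound 4 the estimated value is 20000 nM, with an expected range of 10000 nM to 38000 nM.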

Compound 4, half-maximal inhibitory concentration: 13100 nM
Compound 4: the middle estimate sits 1.5-fold (0.18 log units) above what was measured, within the range that was stated.
By their numbers in this assay, from the lowest: compounds 4, 3, 1 and 2 (each within the scatter of the next, the first and the last beyond it).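

In this assay, 4-methylphenyl in place of 3-methoxyphenyl on this aromatic carbon gives a 1.3-fold lower number from compound 3 to compound 4 (0.11 log units; within the scatter), so a group without the hydrogen-bond acceptor of 3-methoxyphenyl stays within the scatter here. The other new comparison, 1,3-benzothiazol-2-yl in place of 5,6-dimethyl-1,3-benzothiazol-2-yl on the amine nitrogen, gives a 1.7-fold lower number from compound 1 to compound 4 (0.23 log units; within the scatter) and also stays within the scatter. No measured evidence accounts for either step.

The substituent and its place on the phenyl ring change together, so neither can be read alone. Going by these compounds, whether an amine or a carboxylic acid on that ring would give a step beyond the scatter remains open.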